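The source may hold more compounds than are shown below. What is called first, only, known or untested is meant among the compounds shown, and "the series" means these compounds.

Compound 1 `CC(C)(C)n1nc(Cc2ccc(Cl)cc2)c2ccccc2c1=O`; compound 2 `C=CCn1nc(Cc2ccc(Cl)cc2)c2ccccc2c1=O`; compound 3 `Cn1nc(Cc2ccc(Cl)c(Cl)c2)c2ccccc2c1=O`.

In a functional assay on aorta with Alpha-1D adrenergic receptor (Rattus norvegicus) as the target (on this read-out higher numbers stand for an effect only at larger amounts of compound and lower numbers for an effect already at smaller amounts), compound 1 reaches only the limit of the assay, > 100000 nM, and no number. In this assay compound 2 gives 2600 nM. In this assay compound 3 gives 4900 nM, and the gap between compound 3 and compound 2 lies within the usual scatter, so the two cannot be told apart; these are the only two real numbers shown.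

Compound 4 `Cn1nc(Cc2ccc(Cl)cc2)c2ccccc2c1=O` differs from compound 3 by hydrogen in place of chloro on an aromatic carbon. Among the compounds with values here, the one measured step, an at least 38-fold lower number from compound 1 to compound 2 (1.58 log units; beyond the scatter), concerns the group on the nitrogen and not this ring, so it gives no direct guide. Compound 4 is therefore expected to stay close to compound 3, with the step of a 1.4-fold higher number from compound 3 to compound 4 (0.15 log units; within the scatter) expected to remain within or only just beyond the scatter. Compound 4 is estimated at 7000 nM, in the range 2500 nM to 20000 nM.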

Compound 4, half-maximal effective concentration: 430 nM
For compound 4 the middle estimate is 16-fold (1.21 log units) above the measured one; the whole stated range lies above it.
By their numbers in this assay, from the lowest: compound 4; then compounds 2 and 3 (each within the scatter of the next). At a limit, above all of these: compound 1.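

In this assay, within the data shown here, this aromatic carbon proves sensitive, which the earlier compounds could not show: taking off its chloro gives an 11-fold lower number from compound 3 to compound 4 (1.06 log units; beyond the scatter), so the added chloro costs potency here. With this ring unchanged, methyl on the nitrogen also outdoes allyl, with a 6.0-fold lower number from compound 2 to compound 4 (0.78 log units; beyond the scatter), and tert-butyl, with an at least 230-fold lower number from compound 1 to compound 4 (2.36 log units; beyond the scatter). That last step is only a bound, as compound 1 stands at a limit: the limit of > 100000 nM in this assay, at which 1 of the 4 values shown sits.

Open, going by these compounds, is whether a fluoro or a methoxy on this carbon would match hydrogen or chloro. Also open, on these data alone, is how an ethyl on the nitrogen would compare with methyl.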